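Swapping cyclopentyl for cyclobutyl on compound 1

The source may hold more compounds than are shown below. What is called first, only, known or untested is meant among the compounds shown, and "the series" means these compounds.

Values so far in an ADME assay on a cell-free system (plasma, Homo sapiens) (on this read-out lower numbers stand for a smaller free fraction and higher numbers for a larger free fraction), are these:
Compound 1 (`CC(=O)Nc1cc(-c2ccc(N(C)C(=O)c3c(F)cccc3Cl)c(N3CC4CC4C3)c2)n(C2CCCC2)n1`) gives 0.002
Compound 2 (`CC(=O)Nc1cc(-c2cnc(N(C)C(=O)c3c(F)cccc3Cl)c(N3CC4CC4C3)c2)n(C(C)C)n1`) gives 0.056

Compound 1 holds the lower of these two numbers, and the gap up to compound 2 lies well beyond the usual scatter of repeated measurements. These two compounds differ in more than one place, so their gap cannot be pinned on any single group.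

Compound 3 (`CC(=O)Nc1cc(-c2ccc(N(C)C(=O)c3c(F)cccc3Cl)c(N3CC4CC4C3)c2)n(C2CCC2)n1`) keeps the core of compound 1 and changes one thing: cyclobutyl in place of cyclopentyl on an aromatic nitrogen. For the measured compounds named here, no measured pair shows this change on its own, so the expectation rests only on how small the change is. In this assay a small step towards a larger free fraction is expected, and it may well stay within the scatter. An estimated 1.5-fold higher number from compound 1 to compound 3 (0.18 log units; within the scatter) is what this expectation means in numbers. Compound 3 is expected at 0.003 (range 0.0015 to 0.007).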

Compound 3, unbound fraction: 0.003
The estimate for compound 3 equals the measured number at the digits printed, within the range that was stated.
By their numbers in this assay, from the lowest: compounds 1 and 3 (each within the scatter of the next); then compound 2.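

For the compounds shown here, this is the first pair here that differs in one place only, so the change can be read on its own: in this assay, cyclobutyl in place of cyclopentyl on an aromatic nitrogen gives a 1.5-fold higher number from compound 1 to compound 3 (0.18 log units; within the scatter). On the core of compound 1, then, this swap between two rings of carbon only does not separate the two compounds in this assay, and the pair offers no sign that this ring size matters at this position. No measurement shown here gives a reason for this result.

The compounds shown leave open whether a group of another kind on this aromatic nitrogen, such as an amine, a carboxylic acid or a ring containing oxygen like oxetanyl, would move the free fraction beyond the scatter. As far as these compounds go, this is also a single pair on a single core, so whether the same swap would give a similar step on the core of compound 2, which differs from compound 1 in more than one place, remains unknown.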